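The compounds below may be only part of what the source reports. "The series", "measured", "known", "first", "only" and "open" are said of these compounds alone.

Measured so far in a functional assay on DU-145 cells (Homo sapiens) for cytotoxicity, read by MTT assay; a lower number here means a stronger inhibitor, a higher number a weaker inhibitor:
Compound 1, `CC(=O)OCCC(=O)O[C@H](CC=C(C)C)C1=CC(=O)c2c(O)ccc(O)c2C1=O`, gives 15700 nM.
Compound 2, `CCC(C)(O)CC(=O)O[C@H](CC=C(C)C)C1=CC(=O)c2c(O)ccc(O)c2C1=O`, gives 16000 nM.
Compound 3, `CCC(CO[C@H](CC=C(C)C)C1=CC(=O)c2c(O)ccc(O)c2C1=O)OC(C)=O`, gives 25400 nM.

Compound 3 shows the highest of these three numbers, but its gaps to compound 2 and to compound 1 both lie within the scatter, so the three are not told apart by this assay. Compound 4, `CC(C)=CC[C@@H](OC(=O)CC(C)(O)C(C)C)C1=CC(=O)c2c(O)ccc(O)c2C1=O`, differs from compound 3 in one place: (2-hydroxy-2,3-dimethylbutyl)carbonyl in place of 2-acetoxybutyl on an oxygen on a saturated carbon. Among the compounds with values here, two measured steps bear on this: a 1.6-fold higher number from compound 1 to compound 3 (0.21 log units; within the scatter) and a 1.6-fold higher number from compound 2 to compound 3 (0.20 log units; within the scatter), each replacing a carbonyl-bearing chain on that oxygen with 2-acetoxybutyl, and each within the scatter. Compound 4 brings back a carbonyl-bearing chain, so the step of a 1.6-fold lower number from compound 3 to compound 4 (0.20 log units; within the scatter) is expected to be small, at most a slight fall in this assay. Compound 4 is therefore estimated at 16000 nM, with a range from 8000 nM to 35000 nM.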

Compound 4, half-maximal inhibitory concentration: 16900 nM
Estimate against measurement, compound 4: 1.1-fold (0.02 log units) below, and the stated range covers the measured number.
By their numbers in this assay, from the lowest: compounds 1, 2, 4 and 3 (each within the scatter of the next).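

In this assay the extra methyl on a saturated chain carbon bound to two saturated chain carbons gives a 1.1-fold higher number from compound 2 to compound 4 (0.02 log units; within the scatter) and leaves the number in place. The larger swaps read the same way, with a 1.5-fold lower number from compound 3 to compound 4 (0.18 log units; within the scatter) and with a 1.1-fold higher number from compound 1 to compound 4 (0.03 log units; within the scatter) as well, so neither (2-hydroxy-2,3-dimethylbutyl)carbonyl nor 2-acetoxybutyl on this oxygen sets a compound apart. Going by these compounds, whether an amine, a carboxylic acid or a much longer chain here would move the number stays open. No available evidence offers a reason for this flat picture.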